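Moving the fluorine on the aryl ring of compound 3

This account rests on a few compounds, and the source may have more. Where it says the series, first, only, none or still open, it means among the compounds named here.

Three compounds have been measured in a functional assay on Right cardiac atrium for agonist activity at histamine H2 receptor (Cavia porcellus), with a stated time of 30 min, in the presence of a further agent that is not named here; a lower number here means a smaller maximal response, a higher number a larger maximal response:
compound 1 `Cc1nc(N)sc1CCCN/C(N)=N/C(=O)NC(C)c1ccc(Cl)cc1` gives 0.93;
compound 2 `Cc1ccc(C(C)NC(=O)/N=C(\N)NCCCc2sc(N)nc2C)cc1` gives 0.85;
compound 3 `Cc1nc(N)sc1CCCN/C(N)=N/C(=O)NC(C)c1ccc(F)cc1` gives 0.92.

Compound 3 sits in the middle of these three numbers, with a number 0.010 lower from compound 1 to compound 3 (within the scatter) and a number 0.070 higher from compound 2 to compound 3 (within the scatter), both within the scatter, so the three cannot be told apart. Compound 4 `Cc1nc(N)sc1CCCN/C(N)=N/C(=O)NC(C)c1cccc(F)c1` differs from compound 3 only in where the fluorine sits on the ring: 3-fluorophenyl in place of 4-fluorophenyl on a saturated chain carbon bound to an amide-type nitrogen and a saturated chain carbon. For the measured compounds named here, no measured step moves a group around this ring; the known steps swap one group for another at the same place, a number 0.080 lower from compound 1 to compound 2 (within the scatter), a number 0.010 lower from compound 1 to compound 3 (within the scatter) and a number 0.070 higher from compound 2 to compound 3 (within the scatter), each within the scatter. The expectation for compound 4 is therefore no step beyond the scatter, a number 0.020 lower from compound 3 to compound 4 (within the scatter). Compound 4 is estimated at 0.9, between 0.8 and 1.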

Compound 4, intrinsic activity: the largest response reached, as a fraction of the reference agonist's: 0.85
Compound 4: the middle estimate sits 0.050 above what was measured, within the range that was stated.
By their numbers in this assay, from the lowest: compounds 2, 4, 3 and 1 (each within the scatter of the next).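

Moving the fluorine, with 3-fluorophenyl in place of 4-fluorophenyl, is the first change of place on this ring, and it gives a number 0.070 lower from compound 3 to compound 4 (within the scatter) in this assay, so the two placements cannot be told apart. The comparisons with the other compounds read the same way, with no change at the digits printed from compound 2 to compound 4 (within the scatter) and a number 0.080 lower from compound 1 to compound 4 (within the scatter). No outside information bears on these results.

Every step among these four compounds lies within the scatter. On these data alone, whether a methoxy group or an amine on this ring would give a clearly different maximal response remains open.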